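This account rests on a few compounds, and the source may have more. Where it says the series, first, only, none or still open, it means among the compounds named here.

The measured compounds:
compound 1, `C=C[C@](C)(O)CC[C@H]1C(C)=CC[C@H]2C(C)(C)CCC[C@]12C`; in a functional assay on SK-OV-3 cells (Homo sapiens) for cytotoxicity, read by sulforhodamine B assay (on this read-out higher numbers stand for an effect only at larger amounts of compound and lower numbers for an effect already at smaller amounts), compound 1 gives 8.7 ug/mL.
compound 2, `C=C[C@@](C)(CC[C@@H]1[C@@]2(C)CCCC(C)(C)[C@@H]2CC[C@@]1(C)O)O[C@@H]1O[C@H](C)[C@H](O)[C@H](O)[C@H]1O`; in this assay compound 2 gives only a limit, > 5 ug/mL, and no number.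
compound 3, `C=C[C@@](C)(CC[C@H]1C(C)=CC[C@H]2C(C)(C)CCC[C@]12C)O[C@@H]1O[C@@H](C)[C@@H](OC(C)=O)[C@H](O)[C@H]1O`; in this assay compound 3 gives 3.4 ug/mL.

Compound 2 therefore does not stand on a number at all: it sits at the limit of > 5 ug/mL in this assay, at which 1 of the 3 values shown sits, and its true value could lie anywhere beyond that limit. Compound 1 and compound 3 both sit at numbers, and the two of them are within the usual scatter of one another.

Compound 4, `C=C[C@@](C)(CC[C@@H]1[C@@]2(C)CCCC(C)(C)[C@@H]2CC[C@@]1(C)O)O[C@H]1O[C@H](C)[C@H](O)[C@@H](O)[C@@H]1O`, has not been measured in this assay. It shares every atom and bond with compound 2 and differs only in how the sugar is drawn: the two compounds have the same atoms and bonds and differ only in configuration as drawn: 3 of 10 stereo elements differ; a stereocentre at a saturated ring carbon is drawn S in compound 2 and R in compound 4; a stereocentre at a saturated ring carbon is drawn S in compound 2 and R in compound 4; a stereocentre at a saturated ring carbon is drawn R in compound 2 and S in compound 4.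

Within the data shown here, no pair of measured compounds that differ in a single place is available, so no measured step can be pointed to for this kind of change. Since the change touches only configuration and nothing enters or leaves, the step from compound 2 to compound 4 is expected to be none beyond the scatter, with the sign of the step uncertain. The value of compound 4 in this assay is thus estimated at 10 ug/mL, with a range from 4 ug/mL to 30 ug/mL, which means an expected step that the limit leaves unreadable from compound 2 to compound 4.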

Compound 4, concentration for half-maximal effect: > 5 ug/mL
Compound 4: only a limit was reported; the forecaster's own chance of this, stated with the estimate: 55%; the middle value is on the limit's open side.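

In this assay compound 2 and compound 4 each rest on a limit and not on a number, so no step between them can be read: the limit of > 5 ug/mL in this assay, at which 2 of the 4 values shown sit.

The compounds shown leave open whether the configuration of the sugar, the only thing that separates compound 2 from compound 4, changes the read-out at all.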